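Opening a Piperidine into a Sulfonamide Chain

The source may hold more compounds than are shown below. What is called first, only, known or untested is meant among the compounds shown, and "the series" means these compounds.

Compound 1, `Cc1nc(N(C)C2CCCC2)nc2ccc(NC(=O)/C=C/c3ccc(Cl)cc3)cc12`: 57 nM
Compound 2, `Cc1nc(N2CCC(NS(=O)(=O)N(C)C)CC2)nc2ccc(NC(=O)/C=C/c3ccc(OC(F)(F)F)cc3)cc12`: 31 nM
Compound 3, `COCC(=O)NC1CCN(c2nc(C)c3cc(NC(=O)/C=C/c4ccc(OC(F)(F)F)cc4)ccc3n2)CC1`: 14 nM

In a functional assay on CHO-K1 cells for antagonist activity at melanin-concentrating hormone receptor 1 (Homo sapiens), read by inositol phosphate accumulation, with stated times of 10 min and 45 min (a higher number here means a weaker inhibitor, a lower number a stronger inhibitor), compound 3 gives the lowest number of the three; compound 2 sits above it beyond the scatter, and compound 1 higher still. Compound 4, `Cc1nc(NCCCNS(C)(=O)=O)nc2ccc(NC(=O)/C=C/c3ccc(OC(F)(F)F)cc3)cc12`, differs from compound 3 in one place: (3-(methanesulfonamido)propyl)amino in place of 4-(((methoxymethyl)carbonyl)amino)piperidin-1-yl on an aromatic carbon. Within the data shown here, the only measured step that touches this region is a 2.2-fold lower number from compound 2 to compound 3 (0.35 log units; beyond the scatter), where a sulfonamide gave way to an amide. Compound 4 moves back to a sulfonamide while also losing the ring, so a modest upward step, or none beyond the scatter, is expected. Compound 4 is therefore estimated at 40 nM, between 12 nM and 130 nM. That expectation amounts to a 2.9-fold higher number from compound 3 to compound 4 (0.46 log units; beyond the scatter).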

Compound 4, half-maximal inhibitory concentration: 32 nM
Compound 4: the middle estimate sits 1.3-fold (0.10 log units) above what was measured, within the range that was stated.
By their numbers in this assay, from the lowest: compound 3; then compounds 2, 4 and 1 (each within the scatter of the next).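

In this assay replacing 4-(((methoxymethyl)carbonyl)amino)piperidin-1-yl with the ringless (3-(methanesulfonamido)propyl)amino gives a 2.3-fold higher number from compound 3 to compound 4 (0.36 log units; beyond the scatter) and so costs only a modest step. At this aromatic carbon, the six-membered ring is therefore not needed for activity of this order, which the earlier step could not show with the ring kept in place.

Ring and end group change together here, so their shares of the step stay unseparated, and it remains open how an amine, a carboxylic acid or a longer chain would fare at this position. Nothing measured here accounts for the step.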